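The source may hold more compounds than are shown below. What is called first, only, known or untested is meant among the compounds shown, and "the series" means these compounds.

Of the compounds shown here, three built on one shared core have been measured in an assay on Sf9 cells for inhibition of mitogen-activated protein kinase kinase kinase 14 variant S549D (Homo sapiens), with a stated time of 30 min, in the presence of a further agent that is not named here; on this read-out lower numbers stand for stronger inhibition and higher numbers for weaker inhibition. Compound 1 `C=CC(=O)NCC#Cc1ccc2ncn(-c3ccnc(N)n3)c2c1` gives 6310 nM. Compound 2 `C#Cc1cc(C#Cc2ccc3ncn(-c4ccnc(N)n4)c3c2)ccn1` gives 31600 nM. Compound 3 `C#Cc1ccnc(C#Cc2ccc3ncn(-c4ccnc(N)n4)c3c2)c1` gives 316 nM, the lowest of the three numbers; its nearest neighbour is compound 1, as the step of a 20-fold lower number from compound 1 to compound 3 (1.30 log units; beyond the scatter) shows, and its furthest is compound 2, as the step of a 100-fold lower number from compound 2 to compound 3 (2.00 log units; beyond the scatter) shows. Compound 2 and compound 3 carry the same count of atoms and the same kind of ring, so the step between them shows that rearranging the same atoms on the triple-bonded carbon can move the read-out by a large amount. The step of a 5.0-fold higher number from compound 1 to compound 2 (0.70 log units; beyond the scatter) is smaller.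

Compound 4 `C=Cc1ccnc(C#Cc2ccc3ncn(-c4ccnc(N)n4)c3c2)n1` has not been measured. It differs from compound 3 in one place: a group of 8 heavy atoms (6 carbon, 2 nitrogen; one six-membered aromatic ring with 2 hetero atoms) in place of a group of 8 heavy atoms (7 carbon, 1 nitrogen; one six-membered aromatic ring with 1 hetero atom), on a triple-bonded carbon. For the measured compounds named here, no measured pair swaps a ring with one hetero atom for one with two, nor a triple bond outside the ring for a double bond, so the steps that bear on it do so only loosely; they are those that change the group on the triple-bonded carbon, of which a 100-fold lower number from compound 2 to compound 3 (2.00 log units; beyond the scatter) is the largest and a 20-fold lower number from compound 1 to compound 3 (1.30 log units; beyond the scatter) the next. Since such changes have moved this assay by large amounts in both directions, a modest step towards a higher number is expected for compound 4, a 2.5-fold higher number from compound 3 to compound 4 (0.40 log units; beyond the scatter). Compound 4 is estimated at 800 nM, within 200 nM to 4000 nM.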

Compound 4, half-maximal inhibitory concentration: 1580 nM
Beside the measured number, compound 4's estimate is 2.0-fold (0.30 log units) below it; measured number inside the range.
By their numbers in this assay, from the lowest: compound 3; then compound 4; then compound 1; then compound 2.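

In this assay the change on the triple-bonded carbon to a ring with 2 hetero atoms and a double bond outside it costs little against 4-ethynylpyridin-2-yl (a 5.0-fold higher number from compound 3 to compound 4 (0.70 log units; beyond the scatter)), yet compound 4 keeps most of the gain that compound 3 showed over the weakest compound (a 20-fold lower number from compound 2 to compound 4 (1.30 log units; beyond the scatter)). The new group also gives a lower number than the open-chain group with no ring (a 4.0-fold lower number from compound 1 to compound 4 (0.60 log units; beyond the scatter)), so a second aromatic group at this place can outdo that chain, while compound 2 goes against any rule that an aromatic ring here is enough. Compound 4 changes the ring and the unsaturated bond together, so its step cannot be shared out between them, and nothing available accounts for its size.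

The compounds shown leave open whether the second ring nitrogen or the loss of the triple bond carries the step, which the ethynyl group on the ring of compound 4 or the vinyl group on the ring of compound 3 would separate. They also leave open how a saturated ethyl group or an amine on either ring would read.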